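Phenyl for Ethyl on the Amine Nitrogen: Expected Cytotoxicity

This account rests on a few compounds, and the source may have more. Where it says the series, first, only, none or still open, it means among the compounds named here.

Compound 2 `CCN/C(SC)=C(/C#N)C(=O)Nc1ccc(OCC)cc1` was tested in an ADME assay on TERT-RPE1 cells (Homo sapiens) for cytotoxicity, read by resazurin assay, with a stated time of 48 h; a higher number here means a weaker inhibitor, a lower number a stronger inhibitor. There compound 2 gives only a limit of the assay, > 100000 nM. Compound 1 `CCOc1ccc(NC(=O)c2c(N)n[nH]c2NC)cc1` likewise returns only a limit, > 100000 nM. Compound 3 `CCOc1ccc(-n2nnc3n[nH]c(NC)c3c2=O)cc1` also returns only a limit, > 100000 nM. All three results thus share (the limit of > 100000 nM in this assay, at which 3 of the 3 values shown sit). Compound 4 `CCOc1ccc(NC(=O)/C(C#N)=C(\Nc2ccccc2)SC)cc1` has not yet been measured in this assay. It differs from compound 2 in one place: phenyl in place of ethyl on an amine nitrogen, or read one bond further out, ethylamino to anilino. Within the data shown here, no step between measured compounds exists, so the data give no direction. The step of a number no higher from compound 2 to compound 4 (the limit leaves the size open) is expected to stay within the scatter. Compound 4 is estimated at 100000 nM, between 30000 nM and 300000 nM.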

Compound 4, half-maximal inhibitory concentration: > 100000 nM
Compound 4: no number, only a limit; the forecaster's own chance of this, stated with the estimate: 75%; the middle value sits exactly at the limit.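

Compound 2 and compound 4 both return only a limit in this assay, so no step can be read between them: the limit of > 100000 nM in this assay, at which 4 of the 4 values shown sit.

The compounds shown leave open whether phenyl in place of ethyl on an amine nitrogen changes cytotoxicity at all.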